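A Sulfur-Bearing Group in Place of a Dichlorophenyl Urea

The compounds below may be only part of what the source reports. "The series", "measured", "known", "first", "only" and "open" are said of these compounds alone.

Of the compounds shown here, three sharing one core have been measured in a functional assay on RS4-11 cells (Homo sapiens) for inhibition, read by CCK-8 assay, with a stated time of 48 h; a higher number here means a weaker inhibitor, a lower number a stronger inhibitor. Compound 1 `COc1ccc(NC(=O)NCCNS(=O)(=O)c2ccc(-c3ccccc3OCc3ccccc3)s2)cc1` reports only a limit, > 20000 nM. Compound 3 `O=C(NCCNS(=O)(=O)c1ccc(-c2ccccc2OCc2ccccc2)s1)Nc1cc(Cl)cc(Cl)c1` likewise reports only a limit, > 20000 nM, so it has no exact number to start from. Among the compounds with values here, compound 2 `O=[N+]([O-])c1ccc(NC(=S)NCCNS(=O)(=O)c2ccc(-c3ccccc3OCc3ccccc3)s2)cc1`, the one measured compound whose group carries sulfur, gives 11300 nM.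

The change to compound 4 `O=S(=O)(NCCNC(=S)Nc1ccc(Cl)cc1)c1ccc(-c2ccccc2OCc2ccccc2)s1` is a group of 10 heavy atoms (7 carbon, 1 nitrogen, 1 sulfur, 1 chlorine; one six-membered aromatic ring of carbon only) in place of a group of 11 heavy atoms (7 carbon, 1 nitrogen, 1 oxygen, 2 chlorine; one six-membered aromatic ring of carbon only), on an amine nitrogen. Here too, the entering group carries sulfur where the leaving group carries oxygen. Within the data shown here, two measured steps bear on this: an at least 1.7-fold lower number from compound 1 to compound 2 (0.24 log units; that floor lies within the scatter), and an at least 1.7-fold higher number from compound 2 to compound 3 (0.24 log units; that floor lies within the scatter). Both are only floors, so neither fixes the true size of the step.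

On the precedent of compound 2 at 11300 nM, a small move to a lower number is expected in this assay. A further limit would not be surprising. The estimated step is an at least 1.8-fold lower number from compound 3 to compound 4 (0.25 log units; that floor lies within the scatter). Compound 4 is expected at 11000 nM, within an estimated range of 5000 nM to 20000 nM.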

Compound 4, half-maximal inhibitory concentration: > 50000 nM
Compound 4 was reported as a limit; the forecaster's own chance of this, stated with the estimate: 35%; at least 4.5-fold (0.65 log units) between middle value and limit.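

In this assay, compound 4 reports only a limit, > 50000 nM. Within the data shown here, with the sulfur-bearing group kept, chloro in place of nitro on an aromatic carbon gives an at least 4.4-fold higher number from compound 2 to compound 4 (0.64 log units; beyond the scatter), a step beyond the scatter that the earlier floors could not show; sulfur in the group therefore does not by itself go with a measured value, and compound 2 remains the only compound here with an exact number. The steps to compound 4 from compound 1 and from compound 3 cannot be read, as each joins two limits.

The compounds shown do not separate the effect of sulfur against oxygen from that of the group on the aromatic ring, as no pair here differs in that atom alone. From the compounds shown here alone, whether the nitro group of compound 2 can give way to a nitrile, a carboxylic acid or an amine on that aromatic carbon remains open.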